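Hydroxy added to the benzylamide ring of compound 3

This account rests on a few compounds, and the source may have more. Where it says the series, first, only, none or still open, it means among the compounds named here.

Compound 3 `O=C(NCc1ccccc1)[C@@H]1CCC(=O)N1Cc1ccccc1` is the smallest member of the set shown here. In an assay on HEK293 cells for inhibition of Ataxin-2 (Mus musculus), read by fluorescence and Amplex Red (a higher number here means a weaker inhibitor, a lower number a stronger inhibitor), compound 3 gives only a limit, > 5000 nM, and no number. Compound 1 `NS(=O)(=O)c1ccc(COc2ccc(CNC(=O)[C@@H]3CCC(=O)N3Cc3ccc(C(F)(F)F)cc3)cc2)cc1` behaves the same way: in this assay compound 1 gives > 5000 nM, again a limit. Going by the values given here, compound 2 `CC1(C)OB(c2ccc(COc3ccc(CNC(=O)[C@H]4CCC(=O)N4Cc4ccccc4)cc3)cc2)OC1(C)C` is the one member with a number, and in this assay compound 2 gives 180 nM. Both limits sit at the limit of > 5000 nM in this assay, at which 2 of the 3 values shown sit.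

Compound 4 `O=C(NCc1ccc(O)cc1)[C@@H]1CCC(=O)N1Cc1ccccc1` differs from compound 3 in one place: hydroxy in place of hydrogen on an aromatic carbon, para to a large group. Among the compounds with values here, no measured pair of this kind exists in the set, so the size of such a step in this assay cannot be read from the data. Compound 2 is far larger than compound 3 and reaches a number, while compound 1, also large, stays at its limit; a single hydroxy is a much smaller addition than either. The expectation for compound 4 is therefore that the step of a number no higher from compound 3 to compound 4 (the limit leaves the size open) brings at most a small gain, not beyond the scatter, and that compound 4 most likely remains at the limit. The estimate for compound 4 in this assay is 5000 nM, within 2000 nM to 20000 nM.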

Compound 4, half-maximal inhibitory concentration: > 5000 nM
Compound 4 was reported as a limit; the forecaster's own chance of this, stated with the estimate: 70%; the middle value sits exactly at the limit.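

Compound 3 and compound 4 are both reported only as limits in this assay, so no step between them can be read: the limit of > 5000 nM in this assay, at which 3 of the 4 values shown sit.

The compounds shown leave open whether hydroxy in place of hydrogen on an aromatic carbon changes the half-maximal inhibitory concentration at all in this assay, and in which direction.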